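The source may report more compounds than this note shows. Statements on the series, on what has been measured and on what is new or still open speak of the compounds shown alone.

Measured so far in a physicochemical assay for lipophilicity; a higher number here means a more lipophilic compound, a lower number a more polar compound:
Compound 1 `CC(=O)NCc1cccc(Cn2nc(NS(=O)(=O)c3ccc(Cl)s3)c3c(O)cccc32)c1`: 2.9
Compound 2 `COc1cccc2c1c(NS(=O)(=O)c1ccc(Cl)s1)nn2Cc1cc(CNC(C)=O)ccn1`: 2.6

In this assay compound 2 gives 2.6, which lies within the scatter of compound 1 at 2.9, so the two cannot be told apart on these numbers. Compound 3 `COc1cccc2c1c(NS(=O)(=O)c1ccc(Cl)s1)nn2Cc1cccc(CNC(C)=O)n1` has not yet been measured. It has the same atoms as compound 2, joined differently: 6-(acetamidomethyl)pyridin-2-yl in place of 4-(acetamidomethyl)pyridin-2-yl on a saturated chain carbon bound to an aromatic nitrogen. The group on the saturated chain carbon bound to an aromatic nitrogen therefore stays an acetamidomethyl-bearing pyridin-2-yl, and only the position of its side chain changes from 4 to 6. For the measured compounds named here, no measured pair in this small set isolates such a change, so the expectation rests on compound 2 at 2.6 and on the unchanged counts. The expected change is a number 0.10 log units higher from compound 2 to compound 3 (within the scatter), which would be no step beyond the scatter. For compound 3 the estimated value is 2.7, with an expected range from 2.3 to 3.1.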

Compound 3, distribution coefficient: 3
Compound 3: the middle estimate sits 0.30 log units below what was measured; low and high end bracket the measured number.
By their numbers in this assay, from the lowest: compounds 2, 1 and 3 (each within the scatter of the next, the first and the last beyond it).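

In this assay, for the compounds shown here, 6-(acetamidomethyl)pyridin-2-yl in place of 4-(acetamidomethyl)pyridin-2-yl gives a number 0.40 log units higher from compound 2 to compound 3 (beyond the scatter) and is the first single change that this set isolates. The atoms and the counted features of the two groups are the same, so at this place, on a saturated chain carbon bound to an aromatic nitrogen, the position of the side chain on the pyridin-2-yl is enough to give a modest step beyond the scatter. Nothing available explains why the read-out moves with this change.

This single pair leaves open whether a step of this size would recur with a different side chain on the pyridin-2-yl. An aminomethyl group or a carboxylic acid in place of the acetamidomethyl would test that, and a longer chain could test it further.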